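The source may report more compounds than this note shows. Statements on the series, on what has been measured and on what is new or still open speak of the compounds shown alone.

Measured in a functional assay on HT-29 cells (Homo sapiens) for cytotoxicity, read by MTT assay, with a stated time of 24 h; a lower number here means a stronger inhibitor, a higher number a weaker inhibitor:
Compound 1 `C#CCOc1ccccc1/C=N/Cc1ccc(S(N)(=O)=O)cc1`: 31000 nM
Compound 2 `C#CCOc1ccc(/C=N/Cc2ccc(S(N)(=O)=O)cc2)cc1`: 14100 nM
Compound 3 `C#CCOc1ccc(Br)cc1/C=N/Cc1ccc(S(N)(=O)=O)cc1`: 45700 nM

Compound 3, at 45700 nM, lies within the scatter of compound 1, while compound 2 lies beyond the scatter from it with a lower number. Compound 4 `C#CCOc1ccc([N+](=O)[O-])cc1/C=N/Cc1ccc(S(N)(=O)=O)cc1` differs from compound 3 as follows: nitro in place of bromo on an aromatic carbon. This is nitro in place of bromo on an aromatic carbon, para to a propargyloxy group. Among the compounds with values here, the one measured step that bears on this carbon is a 1.5-fold higher number from compound 1 to compound 3 (0.17 log units; within the scatter), for bromo in place of hydrogen. Within the data shown here, no nitro compound has been measured, so on this single small step no change beyond the scatter is expected in this assay. The expected step is a 1.3-fold lower number from compound 3 to compound 4 (0.12 log units; within the scatter). Compound 4 is estimated at 35000 nM, with an expected range from 15000 nM to 80000 nM.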

Compound 4, half-maximal inhibitory concentration: 34800 nM
Compound 4: middle estimate off by 1.0-fold (0.00 log units), on the high side; the range from low to high includes it.
By their numbers in this assay, from the lowest: compound 2; then compounds 1, 4 and 3 (each within the scatter of the next).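

In this assay, this carbon, para to a propargyloxy group, now has a second group to compare with hydrogen. Nitro in place of bromo gives (a 1.3-fold lower number from compound 3 to compound 4 (0.12 log units; within the scatter)), and nitro in place of hydrogen gives (a 1.1-fold higher number from compound 1 to compound 4 (0.05 log units; within the scatter)), so hydrogen, bromo and nitro here all stand within the scatter of one another. No evidence is available that would explain this.

Going by these compounds, whether any group on this carbon can move the number beyond the scatter stays open. An amine or a carboxylic acid here would test that.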